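Moving a methoxy group on the ester-linked aromatic ring

The source may report more compounds than this note shows. Statements on the series, on what has been measured and on what is new or still open speak of the compounds shown alone.

This set of compounds shares one core, shown in compound 1 `COC(=O)/C(=C\c1ccc(O)cc1)Sc1ccnc2cc(Cl)ccc12`, where a free hydroxyl sits on the aromatic ring. In a functional assay on HL-60 cells (Homo sapiens) for cytotoxicity, read by MTT assay, with a stated time of 24 h (on this read-out lower numbers stand for stronger inhibition and higher numbers for weaker inhibition), compound 1 gives 4310 nM. Capping that hydroxyl as an ester gives compound 2 `COC(=O)/C(=C\c1ccc(OC(=O)c2ccccc2)cc1)Sc1ccnc2cc(Cl)ccc12`, which in this assay gives 30200 nM; the step of a 7.0-fold higher number from compound 1 to compound 2 (0.85 log units; beyond the scatter) weakens the effect. Adding two methoxy groups to the ester's aromatic ring gives compound 3 `COC(=O)/C(=C\c1ccc(OC(=O)c2ccc(OC)c(OC)c2)cc1)Sc1ccnc2cc(Cl)ccc12`, which gives 5290 nM; the step of a 5.7-fold lower number from compound 2 to compound 3 (0.76 log units; beyond the scatter) recovers most of that loss, and the step of a 1.2-fold higher number from compound 1 to compound 3 (0.09 log units; within the scatter) leaves compound 3 close to compound 1. Compound 3 thus stands second highest of the three numbers, within the scatter of compound 1 and well apart from compound 2.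

Compound 4 `COC(=O)/C(=C\c1ccc(OC(=O)c2ccc(OC)cc2OC)cc1)Sc1ccnc2cc(Cl)ccc12` differs from compound 3 only in how the same atoms are joined: 2,4-dimethoxyphenyl in place of 3,4-dimethoxyphenyl on a carbonyl carbon. Going by the values given here, no measured step tests this rearrangement directly. Among the compounds with values here, the steps that bear on it show that the ester's aromatic ring matters, since the change from phenyl to 3,4-dimethoxyphenyl moved the number beyond the scatter, but they do not show which way a different arrangement of the two methoxy groups would point. A step of about a 1.3-fold higher number from compound 3 to compound 4 (0.12 log units; within the scatter) is therefore expected, with the direction uncertain, so compound 4 is estimated at 7000 nM, somewhere between 2500 nM and 20000 nM.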

Compound 4, half-maximal inhibitory concentration: 7640 nM
For compound 4 the middle estimate is 1.1-fold (0.04 log units) below the measured one; the range from low to high includes it.
By their numbers in this assay, from the lowest: compounds 1, 3 and 4 (each within the scatter of the next); then compound 2.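

In this assay, the change from 3,4-dimethoxyphenyl to 2,4-dimethoxyphenyl on the carbonyl carbon gives a 1.4-fold higher number from compound 3 to compound 4 (0.16 log units; within the scatter), so in this pair the arrangement of the two methoxy groups does not separate the compounds. The gain over the plain phenyl ester is also not tied to the 3,4-dimethoxyphenyl arrangement, since the other arrangement gives a 4.0-fold lower number from compound 2 to compound 4 (0.60 log units; beyond the scatter), a step clearly larger than the usual scatter. Placing (2,4-dimethoxyphenyl)carbonyl on the oxygen in place of hydrogen gives a 1.8-fold higher number from compound 1 to compound 4 (0.25 log units; within the scatter), so both dimethoxy esters remain within the scatter of the free hydroxyl compound, while the plain benzoyl ester of compound 2 does not.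

Still open, from the compounds shown here alone, is how a ring with a single methoxy group, a 3,5-dimethoxyphenyl ring, or a ring carrying an amine, a carboxylic acid or a longer chain such as butoxy would compare on this same carbonyl carbon. Nothing shown here offers an independent measurement that would explain how the two methoxy groups produce the difference from compound 2.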